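This account rests on a few compounds, and the source may have more. Where it says the series, first, only, none or still open, it means among the compounds named here.

The compounds measured so far:
compound 1, `COc1cc(-c2cc(/C=C/C(=O)c3ccc(N)cc3)[nH]n2)cc(OC)c1OC`, 60500 nM
compound 2, `COc1ccc(-c2cc(/C=C/C(=O)c3ccc(N)cc3)[nH]n2)cc1`, 34100 nM
compound 3, `COc1cc(C(=O)/C=C/c2cc(-c3cc(OC)c(OC)c(OC)c3)n[nH]2)cc(OC)c1OC`, 5220 nM

These three compounds share a core and were tested in a functional assay on MCF7 cells (Homo sapiens) for inhibition, read by sulforhodamine B assay, with a stated time of 48 h; on this read-out lower numbers stand for higher toxicity in this test and higher numbers for lower toxicity in this test. Compound 1 shows the highest number of the three in this assay. Compound 2 lies within the scatter of compound 1, so the two cannot be told apart on this read-out. Compound 3 lies clearly below compound 1, a gap that is beyond the scatter, and it is the only one of the three whose value is well separated from compound 1.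

Compound 4, `COc1cc(-c2cc(/C=C/C(=O)c3ccc(F)c(F)c3)[nH]n2)cc(OC)c1OC`, has not yet been measured in this assay. It differs from compound 1 in one place: 3,4-difluorophenyl in place of 4-aminophenyl on a carbonyl carbon. Within the data shown here, no measured pair of compounds shows this same change, so its effect cannot be read from any step among the numbers in hand, and the expectation rests on compound 1 alone.

Compound 4 is expected to sit near compound 1, with the estimated step of a 2.0-fold lower number from compound 1 to compound 4 (0.30 log units; within the scatter) pointing toward a somewhat lower number but possibly staying within the scatter. Compound 4 is therefore estimated to give about 30000 nM in this assay, within a range from 8000 nM to 110000 nM.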

Compound 4, concentration lethal to 50% of the cells: > 100000 nM
Compound 4: only a limit was reported; the forecaster's own chance of this, stated with the estimate: 10%; at least 3.3-fold (0.52 log units) between middle value and limit.
By their numbers in this assay, from the lowest: compound 3; then compounds 2 and 1 (each within the scatter of the next). At a limit, above all of these: compound 4.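

In this assay compound 4 gives > 100000 nM, and this entry is a limit of the assay, not a number, so the result fixes only a floor for this change: the limit of > 100000 nM in this assay, at which 1 of the 4 values shown sits.

Replacing 4-aminophenyl with 3,4-difluorophenyl gives an at least 1.6-fold higher number from compound 1 to compound 4 (0.21 log units; that floor lies within the scatter), so the data do not establish a real rise, though they also show no fall in the number. Among these compounds, the earlier compounds held no pair differing in one place, so this is the first direct reading at this position, and it shows that this change does not move the read-out toward higher toxicity in this test.

Going by these compounds, how far the true value of compound 4 lies from that of compound 1 stays open, as only a limit stands for compound 4. Also open, on these data alone, is how this position would read with a plain phenyl, or with a phenyl carrying a single fluorine or a carboxylic acid, and whether the same change would read alike on the core of compound 2.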